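Bromo in place of methyl on the 4-methylphenyl arm

The compounds below may be only part of what the source reports. "The series", "measured", "known", "first", "only" and "open" are said of these compounds alone.

Measured so far:
compound 1, `C=C1C[C@]23C[C@@]1(O)CC[C@H]2c1ccc(OS(=O)(=O)c2ccc(C)cc2)c(C)c1[C@@H]3Cn1cc(-c2ccc(Br)cc2)nn1`: > 20000 nM
compound 2, `C=C1C[C@]23C[C@@]1(O)CC[C@@H]2c1cccc(C)c1[C@@H]3Cn1cc(-c2ccc(C)cc2)nn1`: > 20000 nM

In a functional assay on A549 cells (Homo sapiens) for cytotoxicity, read by MTT assay, with a stated time of 4 days (on this read-out higher numbers stand for weaker inhibition and lower numbers for stronger inhibition), compound 1 gives > 20000 nM, which is a limit of the assay and not a number. In this assay compound 2 gives > 20000 nM, again a limit rather than a number. Going by the values given here, compound 2 thus stands at the edge of what this assay reports, and the limit of > 20000 nM in this assay, at which 2 of the 2 values shown sit, shows that every value so far sits at that same edge, so no measured step between compounds is available.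

Compound 3 is `C=C1C[C@]23C[C@@]1(O)CC[C@@H]2c1cccc(C)c1[C@@H]3Cn1cc(-c2ccc(Br)cc2)nn1`. It differs from compound 2 in one place: bromo in place of methyl on an aromatic carbon.

Among the compounds with values here, with both known values at the limit and no measured step to lean on, no change beyond the usual scatter is expected in this assay from this swap. Compound 3 is estimated at 25000 nM (range 10000 nM to 60000 nM), most probably reported again as a limit. This estimate means an expected step that the limit leaves unreadable from compound 2 to compound 3, within the scatter.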

Compound 3, half-maximal inhibitory concentration: > 20000 nM
Compound 3 ended at the assay's limit; the forecaster's own chance of this, stated with the estimate: 85%; the middle value does not contradict the limit.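

Bromo in place of methyl leaves no readable step between compound 2 and compound 3 in this assay, since both values are limits and not numbers: the limit of > 20000 nM in this assay, at which 3 of the 3 values shown sit. The compounds shown leave open which change to the shared core or its arms would give a numerical value in this assay.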